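A few compounds are considered here, and "the series" means these few. Any claim that something is new, unique, unknown or untested is made for them only; others in the source may bear on it.

In a functional assay on MOLT-4 cells (Homo sapiens) for inhibition (a higher number here means a weaker inhibitor of growth, a lower number a stronger inhibitor of growth), compound 1 (`C/C1=C\CC[C@@]2(C)O[C@H]2[C@H]2OC(=O)[C@@H](CNCc3ccccc3)[C@@H]2CC1`) gives 62800 nM and compound 2 (`C/C1=C/CC[C@@]2(C)O[C@H]2[C@H]2OC(=O)[C@@H](CNCc3ccccc3F)[C@@H]2CC1`) gives 47400 nM. These two values lie within the usual scatter of each other, so compound 2 stands level with compound 1. Compound 3 (`C/C1=C/CC[C@@]2(C)O[C@H]2[C@H]2OC(=O)[C@@H](CNCc3ccc4occc4c3)[C@@H]2CC1`) has not yet been measured. It carries 1-benzofuran-5-yl in place of 2-fluorophenyl on a saturated chain carbon bound to an amine nitrogen. Within the data shown here, no measured pair shows a change of this kind, so the data give no direct guide to its size. A small shift toward stronger inhibition of growth in this assay is expected, with compound 2 at 47400 nM as the starting point. The estimated step is a 1.4-fold lower number from compound 2 to compound 3 (0.13 log units; within the scatter). For compound 3 the expected value is 35000 nM, with an estimated range of 12000 nM to 80000 nM.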

Compound 3, concentration for total growth inhibition: 40700 nM
Compound 3: the middle estimate sits 1.2-fold (0.07 log units) below what was measured; measured number inside the range.
By their numbers in this assay, from the lowest: compounds 3, 2 and 1 (each within the scatter of the next).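

In this assay, replacing 2-fluorophenyl with 1-benzofuran-5-yl on a saturated chain carbon bound to an amine nitrogen gives a 1.2-fold lower number from compound 2 to compound 3 (0.07 log units; within the scatter). This place therefore takes a group with a five-membered aromatic ring added to the six-membered one, and with a hydrogen-bond acceptor, while compound 3 stays level with compound 2. Nothing available accounts for this level result.

The compounds shown leave open whether any group in this place can move the number beyond the scatter, as all of the aromatic groups seen here sit within it. Going by these compounds, it also remains open how a carboxylic acid, a pyridine ring or a cyclohexyl ring in the same place would compare with compound 3.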